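Ester variation on a shared core: cytotoxicity notes

The source may hold more compounds than are shown below. What is called first, only, known or untested is meant among the compounds shown, and "the series" means these compounds.

Measured compounds in an ADME assay on HepG2 2.2.15 cells (Homo sapiens) for cytotoxicity, read by MTT assay, with a stated time of 72 h; a higher number here means that more compound is tolerated, a lower number that less compound is tolerated:
- compound 1, `CCCCCCCC(=O)OCc1cccc2c1CCOC2=O`: > 3450000 nM, a limit of the assay.
- compound 2, `O=C1OCCc2c(COC(=O)C3CCCCC3)cccc21`: > 1840000 nM, a limit of the assay.
- compound 3, `O=C(OCc1cccc2c1CCOC2=O)c1ccco1`: > 2350000 nM, a limit of the assay.

Compound 3 stands at the limit of > 2350000 nM in this assay, at which 1 of the 3 values shown sits. Its value is a limit, not a number, and the two further values are limits as well. The steps a step that the two limits leave unreadable from compound 1 to compound 2, a step that the two limits leave unreadable from compound 1 to compound 3 and a step that the two limits leave unreadable from compound 2 to compound 3 therefore give no readable size; all that can be said is that none of the three esters reached a measurable half-maximal cytotoxic concentration at the tested top.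

Compound 4, `O=C(OCc1cccc2c1CCOC2=O)c1cccnc1`, is not yet measured. It differs from compound 3 by pyridin-3-yl in place of furan-2-yl on a carbonyl carbon. Among the compounds with values here, no measured step bears on this change with a readable size; the three steps between the measured compounds all end at limits. Within the data shown here, the only expectation that the numbers support is that compound 4 is again tolerated to the top of the tested range. The estimated step of a number no higher from compound 3 to compound 4 (the limit leaves the size open) is expected to lie within the scatter. For compound 4 the expected value in this assay is 2350000 nM, with a range from 1000000 nM to 5000000 nM, most likely reported as a limit rather than a number.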

Compound 4, half-maximal cytotoxic concentration: > 2700000 nM
Compound 4 gave a limit, no number (the forecaster's own chance of this, stated with the estimate: 85%); middle value at least 1.1-fold (0.06 log units) from the limit.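

In this assay compound 4 gives > 2700000 nM, a limit and not a number. The steps to compound 4 from compound 1, compound 2 and compound 3 therefore cannot be read. The compounds shown leave open the concentration at which any of these four esters becomes cytotoxic, and whether their ester groups differ in this respect.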